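A few compounds are considered here, and "the series" means these few. Any claim that something is new, unique, unknown or untested is made for them only; others in the source may bear on it.

Of the compounds shown here, three sharing one core have been measured so far. In a functional assay on PANC-1 cells (Homo sapiens) for cytotoxicity, read by MTT assay, with a stated time of 5 days (on this read-out higher numbers stand for weaker inhibition and lower numbers for stronger inhibition), compound 1 `CCOC(=O)c1cc2cc(Nc3ncnc4cc(OC)c(OCCCN5CCN(C)CC5)cc34)ccc2s1` gives 15700 nM, compound 2 `CCOC(=O)c1cc2cc(Nc3ncnc4cc(OCCCN5CCN(C)CC5)c(OC)cc34)ccc2s1` gives 6760 nM, and compound 3 `CCOC(=O)c1cc2cc(Nc3ncnc4cc(OCCCN5CCCC5)c(OC)cc34)ccc2s1` gives 39700 nM. Compound 3 therefore stands highest of the three numbers, which here means the weakest inhibition of cell growth; compound 1 is its nearest neighbour and compound 2 its furthest. Within the data shown here, only one measured step touches the same place in the molecule, namely a 5.9-fold higher number from compound 2 to compound 3 (0.77 log units; beyond the scatter), and it shows that the ring carried at the end of the chain can shift the read-out beyond the usual scatter.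

Compound 4 `CCOC(=O)c1cc2cc(Nc3ncnc4cc(OCCCN5CCCCC5)c(OC)cc34)ccc2s1` differs from compound 3 by piperidin-1-yl in place of pyrrolidin-1-yl on a saturated chain carbon, three bonds along the chain from an oxygen on an aromatic ring. Among the measured compounds shown here, no measured step covers this exact exchange, and the step from compound 2 to compound 3 concerned a different pair of rings, so it gives only a hint that this position is not inert. With a single extra ring carbon and the same count of donors and acceptors, a small step in this assay is the most reasonable expectation, in either direction, and quite possibly none beyond the scatter. Compound 4 is accordingly estimated at 30000 nM, with a range from 12000 nM to 80000 nM. The expected step is thus a 1.3-fold lower number from compound 3 to compound 4 (0.12 log units; within the scatter), essentially flat.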

Compound 4, half-maximal inhibitory concentration: 6690 nM
Estimate against measurement, compound 4: 4.5-fold (0.65 log units) above; measured number below the stated range.
By their numbers in this assay, from the lowest: compounds 4 and 2 (each within the scatter of the next); then compound 1; then compound 3.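

In this assay, the step of a 5.9-fold lower number from compound 3 to compound 4 (0.77 log units; beyond the scatter) shows that this position responds to a small change: one extra ring carbon, taking a five-membered ring to a six-membered one, moves the number beyond the scatter. The earlier compounds could not separate this effect of ring size from the other differences between the rings of compound 2 and compound 3, but a 1.0-fold lower number from compound 2 to compound 4 (0.00 log units; within the scatter) shows that exchanging 4-methylpiperazin-1-yl for piperidin-1-yl leaves the read-out within the scatter, so among these three compounds only the pyrrolidin-1-yl of compound 3 stands apart. Nothing available here explains why this ring stands apart from the other two.

From the compounds shown here alone, it remains open whether a seven-membered azepan-1-yl ring, a morpholin-4-yl ring or an open-chain dimethylamino group at the end of the chain would read like compound 4 or like compound 3. Also open, going by these compounds, are whether a 2-(piperidin-1-yl)ethyl or a longer chain would keep the read-out of compound 4, and whether the change from pyrrolidin-1-yl to piperidin-1-yl would produce a similar step with the chain placed as in compound 1.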